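The source may hold more compounds than are shown below. What is called first, only, known or untested is meant among the compounds shown, and "the series" means these compounds.

Going by the values given here, compound 1 `CN1CCN(CCCS(=O)(=O)c2ccc3nc(NC(=O)NC(=O)c4cccc(-n5cccn5)c4Cl)sc3c2)CC1` is one of three compounds measured in an assay on HEK293 cells for displacement of a labelled ligand from growth hormone secretagogue receptor type 1 (Homo sapiens), with a stated time of 60 min (on this read-out higher numbers stand for weaker inhibition and lower numbers for stronger inhibition), and on that read-out compound 1 gives 8.8 nM, the highest of the three numbers. Among the compounds with values here, compound 2 `CN1CCC(S(=O)(=O)c2ccc3nc(NC(=O)NC(=O)c4cc(N5CCCC5)ccc4Cl)sc3c2)CC1` gives 0.92 nM and compound 3 `CN1CCC(S(=O)(=O)c2ccc3nc(NC(=O)NC(=O)c4cc(N5CCCC5)c(C#N)cc4Cl)sc3c2)CC1` gives 0.4 nM; the one single-point step among the measured compounds, a 2.3-fold lower number from compound 2 to compound 3 (0.36 log units; beyond the scatter), concerns a change at a place that compound 4 does not touch. Compound 4 `CN1CCN(CCCS(=O)(=O)c2ccc3nc(NC(=O)NC(=O)c4cc(C5CC5)ccc4Cl)sc3c2)CC1` has not yet been measured. It differs from compound 1 in one place: 2-chloro-5-cyclopropylphenyl in place of 2-chloro-3-(1H-pyrazol-1-yl)phenyl on a carbonyl carbon. Within the data shown here, no measured step covers this exchange directly. Compound 2, which also carries a group at the fifth position of the chlorophenyl ring but on a different side chain, sits well below compound 1, and this is the only hint available. Compound 4 is therefore expected to come out somewhat stronger than compound 1, with an estimated step of a 2.9-fold lower number from compound 1 to compound 4 (0.47 log units; beyond the scatter). The estimate for compound 4 in this assay is 3 nM, within a range from 0.7 nM to 12 nM.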

Compound 4, half-maximal inhibitory concentration: 0.33 nM
For compound 4 the middle estimate is 9.1-fold (0.96 log units) above the measured one; measured number below the stated range.
By their numbers in this assay, from the lowest: compounds 4 and 3 (each within the scatter of the next); then compound 2; then compound 1.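

Within this assay, the group on the carbonyl carbon proves to be a powerful point of change: with the rest of compound 1 held constant, a 27-fold lower number from compound 1 to compound 4 (1.43 log units; beyond the scatter). This is a large step, whereas the earlier cyano exchange gave only a modest one, a 2.3-fold lower number from compound 2 to compound 3 (0.36 log units; beyond the scatter). The exchange swaps the pyrazole ring for a cyclopropyl ring and also alters the substitution pattern on the chlorophenyl ring, so this single step cannot show which of those two differences matters, and no supporting measurement explains its size.

The compounds shown leave open whether the cyclopropyl ring itself is needed or whether another small carbon group would serve as well. An isopropyl or cyclobutyl group in its place would test that point.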